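Working notes on the acetoxy enone series: compound 3

The source may report more compounds than this note shows. Statements on the series, on what has been measured and on what is new or still open speak of the compounds shown alone.

Compound 2 `COc1ccc(C(=O)/C(=C/c2ccccc2F)CCOC(C)=O)cc1` carries an acetoxymethyl group where compound 1 `COc1ccc(C(=O)/C(=C/c2ccccc2F)COC(C)=O)cc1` carries acetoxy. In a functional assay on A549 cells (Homo sapiens) for inhibition, read by XTT assay, with a stated time of 48 h (a higher number here means a weaker inhibitor, a lower number a stronger inhibitor), compound 1 gives 22500 nM. In this assay compound 2 reaches only the limit of the assay, > 100000 nM. The step of an at least 4.4-fold higher number from compound 1 to compound 2 (0.64 log units; beyond the scatter) is thus known only as a bound, as the limit of > 100000 nM in this assay, at which 1 of the 2 values shown sits, records. Compound 3 `COc1ccc(C(=O)/C(=C/c2ccc(Cl)cc2Cl)CCOC(C)=O)cc1` differs from compound 2 on the aryl side: 2,4-dichlorophenyl in place of 2-fluorophenyl on a double-bonded chain carbon bound to a double-bonded chain carbon. For the measured compounds named here, no measured step touches this aryl position; the only measured step, an at least 4.4-fold higher number from compound 1 to compound 2 (0.64 log units; beyond the scatter), concerns the chain and carries no information on exchanging one halogenated phenyl for another. Compound 2 itself stands at a limit, so its true number may lie anywhere beyond that bound. With nothing to lean on, no shift in this assay beyond the scatter is expected, and the step of a number no higher from compound 2 to compound 3 (the limit leaves the size open) is an estimate of essentially no change. Compound 3 is therefore expected to give about 100000 nM in this assay, within 30000 nM to 300000 nM, with a real chance that the assay again reports only a limit.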

Compound 3, half-maximal inhibitory concentration: 69200 nM
Compound 3: middle estimate off by 1.4-fold (0.16 log units), on the high side, and the stated range covers the measured number.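

The aryl position now has a measured step of its own: 2,4-dichlorophenyl in place of 2-fluorophenyl on a double-bonded chain carbon bound to a double-bonded chain carbon gives an at least 1.4-fold lower number from compound 2 to compound 3 (0.15 log units; that floor lies within the scatter) in this assay. With the acetoxymethyl group unchanged, compound 3 reads as a number, 69200 nM, so this chain does not hold every member of the series at the end of the measurable range. Compound 2 remains a limit, which makes the step a floor whose true size stays unknown: the limit of > 100000 nM in this assay, at which 1 of the 3 values shown sits.

Open is how 2,4-dichlorophenyl behaves with the acetoxy group of compound 1, since the compounds shown give no pair that isolates this aryl change on that shorter chain, and also how far the two aryl groups truly lie apart. Equally open, as far as these compounds go, is what a plain phenyl or a 4-aminophenyl would give at the aryl position, and whether a carboxylic acid or an amine on the chain in place of the acetate ester would keep a measurable number in this assay.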